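Aryl amide series: replacing the amide with an aniline

A few compounds are considered here, and "the series" means these few. Any claim that something is new, unique, unknown or untested is made for them only; others in the source may bear on it.

In a functional assay on LNCaP cells (Homo sapiens) for antiproliferative activity, read by CCK-8 assay, with a stated time of 6 days (a higher number here means a weaker inhibitor, a lower number a stronger inhibitor), compound 3 `C[C@@H](Cn1ccc(-c2ccc(C#N)c(Cl)c2)n1)NC(=O)c1ccccc1F` gives 1810 nM, the lowest of the three numbers shown; compound 2 `COc1ccc(C(=O)N[C@@H](C)Cn2ccc(-c3ccc(C#N)c(Cl)c3)n2)cc1` gives 3410 nM and compound 1 `CC(O)c1ccc(C(=O)N[C@@H](C)Cn2ccc(-c3ccc(C#N)c(Cl)c3)n2)cc1` gives 3690 nM. The steps of a 2.0-fold lower number from compound 1 to compound 3 (0.31 log units; beyond the scatter) and a 1.9-fold lower number from compound 2 to compound 3 (0.28 log units; within the scatter) both change only the ring that sits on the carbonyl. Compound 4 `C[C@@H](Cn1ccc(-c2ccc(C#N)c(Cl)c2)n1)Nc1ccccc1` differs from compound 3 in phenyl in place of (2-fluorophenyl)carbonyl on an amine nitrogen, so the carbonyl itself is removed. Among the measured compounds shown here, no measured step touches the carbonyl, and the steps seen are at most modest, so nothing here shows how the series tolerates its loss. Compound 4 is therefore expected to be a weaker inhibitor, with wide uncertainty, at about 4500 nM (range 900 nM to 20000 nM). The step of a 2.5-fold higher number from compound 3 to compound 4 (0.40 log units; beyond the scatter) is an expectation resting only on these grounds.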

Compound 4, half-maximal inhibitory concentration: 710 nM
Estimate against measurement, compound 4: 6.3-fold (0.80 log units) above; the whole stated range lies above it.
By their numbers in this assay, from the lowest: compound 4; then compounds 3, 2 and 1 (each within the scatter of the next, the first and the last beyond it).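

On the amine nitrogen the carbonyl can go without loss: in this assay, phenyl in place of (2-fluorophenyl)carbonyl gives a 2.5-fold lower number from compound 3 to compound 4 (0.41 log units; beyond the scatter). The change removes the carbonyl and the fluorine together, so this step cannot assign the gain to either one. No supporting data bear on why the number falls.

Still open, on these data alone, is whether a 2-fluorophenyl placed directly on the amine nitrogen matches compound 4. Also open, as far as these compounds go, is how a benzyl group on that nitrogen, or a carboxylic acid on the phenyl, would read.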